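A few compounds are considered here, and "the series" means these few. Any claim that something is new, unique, unknown or untested is made for them only; others in the source may bear on it.

In an ADME assay on microsomes from liver (Homo sapiens) for metabolic stability, read by HPLC, using NADPH, with a stated time of 60 min, tested at 1 uM, in the presence of a further agent that is not named here (a lower number here means slower removal, a higher number faster removal of the compound), compound 1 `O=C(NNS(=O)(=O)c1ccccc1F)c1cc(F)cc(-n2cccn2)c1` gives 18 uL/min, compound 2 `Cc1cc(-c2ncccn2)cc(C(=O)NNS(=O)(=O)c2ccccc2)c1F` gives 11 uL/min, and compound 3 `Cc1cc(-n2cccn2)cc(C(=O)NNS(=O)(=O)c2ccccc2)c1F` gives 23 uL/min. Compound 3 and compound 1 cannot be told apart within the usual scatter, whereas compound 2 sits beyond the scatter: a 2.1-fold higher number from compound 2 to compound 3 (0.32 log units; beyond the scatter). Compound 4 `Cc1cc(-c2ccccn2)cc(C(=O)NNS(=O)(=O)c2ccccc2)c1F` has not yet been measured; it differs from compound 3 in one place: pyridin-2-yl in place of 1H-pyrazol-1-yl on an aromatic carbon. Among the compounds with values here, the only measured step that bears on this is the one just described, where 1H-pyrazol-1-yl replaced pyrimidin-2-yl and the number rose modestly. The present change removes 1H-pyrazol-1-yl again, in favour of pyridin-2-yl. A modest fall beyond the scatter is expected, about a 1.6-fold lower number from compound 3 to compound 4 (0.22 log units; within the scatter). Compound 4 is therefore estimated at 14 uL/min, with a range from 8 uL/min to 28 uL/min.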

Compound 4, intrinsic clearance in a liver preparation (reported as CLH), per the amount of preparation that the assay uses: 27 uL/min
Beside the measured number, compound 4's estimate is 1.9-fold (0.29 log units) below it; low and high end bracket the measured number.
By their numbers in this assay, from the lowest: compounds 2, 1, 3 and 4 (each within the scatter of the next, the first and the last beyond it).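

In this assay, putting pyridin-2-yl in place of 1H-pyrazol-1-yl on this aromatic carbon gives a 1.2-fold higher number from compound 3 to compound 4 (0.07 log units; within the scatter) and so does not separate the two groups. Of the three groups seen here, pyrimidin-2-yl alone stands apart, with a 2.5-fold higher number from compound 2 to compound 4 (0.39 log units; beyond the scatter) as well as a 2.1-fold higher number from compound 2 to compound 3 (0.32 log units; beyond the scatter) on record. No measurement at hand accounts for this difference.

From the compounds shown here alone, it remains open how a non-aromatic group on this carbon, such as an amine or a carboxylic acid, would compare with these rings. Going by these compounds, it is also open whether the same gap holds on a core with other substituents.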